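The source may hold more compounds than are shown below. What is called first, only, known or untested is meant among the compounds shown, and "the series" means these compounds.

Compound 1 `CCN1CCN(CCC(=O)Nc2nc3c(C)cccc3s2)CC1` gives 1200 nM in an assay on membranes from liver for displacement of a labelled ligand from Sigma intracellular receptor 2 (Rattus norvegicus), read by scintillation counting, with a stated time of 120 min (on this read-out lower numbers stand for stronger inhibition and higher numbers for weaker inhibition), the highest of the three numbers in hand. Compound 2 `Cc1cccc2sc(NC(=O)CCN3CCN(C(C)(C)C)CC3)nc12` gives 200 nM and compound 3 `Cc1cccc2sc(NC(=O)CCN3CCN(CC4CCCCC4)CC3)nc12` gives 519 nM. Compound 4 `Cc1cccc2sc(NC(=O)CCN3CCN(C4CCN(C)CC4)CC3)nc12` differs from compound 1 by 1-methylpiperidin-4-yl in place of ethyl on an amine nitrogen in a ring. The bearing steps are a 6.0-fold lower number from compound 1 to compound 2 (0.78 log units; beyond the scatter) and a 2.3-fold lower number from compound 1 to compound 3 (0.36 log units; beyond the scatter), both lower numbers on enlarging the group on the amine nitrogen in the ring; the comparison a 2.6-fold higher number from compound 2 to compound 3 (0.41 log units; beyond the scatter) shows that the size of the gain depends on which group enters. A lower number than compound 1 is therefore expected for compound 4, of modest size, estimated as a 3.0-fold lower number from compound 1 to compound 4 (0.48 log units; beyond the scatter). Compound 4 is expected to give about 400 nM, with a range of 150 nM to 1200 nM.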

Compound 4, inhibition constant: 3600 nM
For compound 4 the middle estimate is 9.0-fold (0.95 log units) below the measured one; measured number above the stated range.
By their numbers in this assay, from the lowest: compound 2; then compound 3; then compound 1; then compound 4.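

In this assay, a larger group on the amine nitrogen in the ring does not always give a lower number: 1-methylpiperidin-4-yl gives a 3.0-fold higher number from compound 1 to compound 4 (0.48 log units; beyond the scatter), against the direction seen with compound 2 and compound 3. The same group also gives a 6.9-fold higher number from compound 3 to compound 4 (0.84 log units; beyond the scatter) and an 18-fold higher number from compound 2 to compound 4 (1.26 log units; beyond the scatter), so enlargement alone does not set the direction at this position. Nothing in hand accounts for this reversal. Open, as far as these compounds go, is whether the rise goes with the nitrogen of the entering ring or with the ring itself; a cyclohexyl group placed directly on the amine nitrogen in the ring would separate the two.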